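A few compounds are considered here, and "the series" means these few. Any claim that something is new, unique, unknown or untested is made for them only; others in the source may bear on it.

Compound 1 `O=C(O)c1ccc(C(=O)/C(=C\c2ccc(Cl)c([N+](=O)[O-])c2)SCc2ccc(F)cc2)cc1`, compound 2 `O=C(O)c1ccc(C(=O)/C(=C\c2ccc(F)c([N+](=O)[O-])c2)SCc2ccc(F)cc2)cc1` and compound 3 `O=C(O)c1ccc(C(=O)/C(=C\c2ccc(Br)c([N+](=O)[O-])c2)SCc2ccc(F)cc2)cc1` share one core and differ only in carrying chloro, fluoro or bromo. In a functional assay on DU-145 cells (Homo sapiens) for inhibition, read by trypan blue exclusion, with a stated time of 96 h (a higher number here means a weaker inhibitor of growth, a lower number a stronger inhibitor of growth), compound 1 gives 1000 nM, compound 2 gives 1000 nM and compound 3 gives 1000 nM, which leaves compound 3 level with the other two.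

The next structure, compound 4 `CC(=O)Nc1ccc(/C=C(/SCc2ccc(F)cc2)C(=O)c2ccc(C(=O)O)cc2)cc1[N+](=O)[O-]`, has acetamido in place of bromo on an aromatic carbon. Three measured steps offer a guide: no change at the digits printed from compound 1 to compound 2 (within the scatter), no change at the digits printed from compound 1 to compound 3 (within the scatter) and no change at the digits printed from compound 2 to compound 3 (within the scatter). They show that swaps among chloro, fluoro and bromo leave this read-out flat, but none of these compounds carries acetamido, so they test this change only loosely. Going by these compounds, no step beyond the scatter is therefore expected in this assay, and the direction remains open, with wide uncertainty. The expected change is a 1.2-fold higher number from compound 3 to compound 4 (0.08 log units; within the scatter). For compound 4 the estimated value is 1200 nM, with an expected range from 350 nM to 4000 nM.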

Compound 4, concentration for 50% growth inhibition: 10000 nM
Compound 4: the middle estimate sits 8.3-fold (0.92 log units) below what was measured; the measured number lies above the stated range.
By their numbers in this assay, from the lowest: compounds 1, 2 and 3 (each within the scatter of the next); then compound 4.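

In this assay chloro, fluoro and bromo at this position left the read-out flat, but acetamido does not: the data show a 10-fold higher number from compound 3 to compound 4 (1.00 log units; beyond the scatter) and a 10-fold higher number from compound 2 to compound 4 (1.00 log units; beyond the scatter) as well as a 10-fold higher number from compound 1 to compound 4 (1.00 log units; beyond the scatter) in a change that means weaker growth inhibition. This position, ortho to a nitro group and para to a large group, therefore tolerates swaps among these halogens but not every substituent. No measurement here explains the loss.

Acetamido differs from the halogens in several ways at once, bringing more heavy atoms, a hydrogen-bond donor and a hydrogen-bond acceptor, so the compounds shown cannot tell which of these features matters. An amine or a methoxy group at the same position would help separate these features, and a longer amide chain would show whether the number keeps rising with size.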